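From Ester to Amide: an Expected Fall in Lipophilicity

The source may report more compounds than this note shows. Statements on the series, on what has been measured and on what is new or still open speak of the compounds shown alone.

Compound 1 `COC(C)(C)CCCC(C)C/C=C/C(C)=C/C(=O)OCCC(C)C` is the least lipophilic of the three compounds measured in a physicochemical assay for lipophilicity (on this read-out lower numbers stand for lower lipophilicity and higher numbers for higher lipophilicity), giving 7.03. Compound 3 `CSC(=O)/C=C(C)/C=C/CC(C)CCCC(C)C` gives 7.44, and compound 2 `CC(/C=C/CC(C)CCCC(C)(C)C)=C\C(=O)OC(C)C` gives 7.56; both stand higher than compound 1 by more than the usual scatter. Compound 4 `COC(C)(C)CCCC(C)C/C=C/C(C)=C/C(=O)NC(C)C` has not yet been measured. It differs from compound 1 in one place: isopropylamino in place of isopentyloxy on a carbonyl carbon. Within the data shown here, no measured pair shows a change of this kind, so the step must be judged from the change itself: the group that enters is smaller than the one that leaves and carries a hydrogen-bond donor instead of an acceptor. A fall in this assay well beyond the scatter is expected, with the step from compound 1 to compound 4 estimated as a number 2.23 log units lower from compound 1 to compound 4 (beyond the scatter). Compound 4 is expected to give 4.8, within a range from 4 to 5.6.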

Compound 4, partition coefficient: 4.45
For compound 4 the middle estimate is 0.35 log units above the measured one, within the range that was stated.
By their numbers in this assay, from the lowest: compound 4; then compound 1; then compounds 3 and 2 (each within the scatter of the next).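

In this assay, among these compounds, isopropylamino in place of isopentyloxy on a carbonyl carbon gives a number 2.58 log units lower from compound 1 to compound 4 (beyond the scatter), the first measured step between compounds that differ in one place. A change at this place can therefore move the read-out well past the usual scatter. No measurement here accounts for the size of the step, and this single pair cannot separate the swap of oxygen for nitrogen from the change in chain. Still open, from the compounds shown here alone, is where isopentylamino, which would carry the chain of compound 1 on nitrogen, would fall on this read-out. Dimethylamino, which has no amide hydrogen, poses the same question.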